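Methyl on the amide-type nitrogen of compound 3

The compounds below may be only part of what the source reports. "The series", "measured", "known", "first", "only" and "open" are said of these compounds alone.

Measured so far in a toxicity assay on MDCK cells (Canis lupus familiaris) for cytotoxicity, read by CCK-8 assay, with a stated time of 48 h; on this read-out higher numbers stand for lower toxicity in this test and lower numbers for higher toxicity in this test:

- compound 1 `CCCCOc1ccc(C(=O)NNc2c(Br)cccc2Br)cc1` gives > 100000 nM as a limit
- compound 2 `O=C(NNc1c(Br)cccc1Br)c1ccc(Br)cc1` gives > 100000 nM as a limit
- compound 3 `CCOc1ccc(C(=O)NNc2c(Cl)cccc2Cl)cc1` gives > 100000 nM as a limit

Compound 3 stands at > 100000 nM as a limit and not as a number. The other two compounds are also known only as limits, and the limit of > 100000 nM in this assay, at which 3 of the 3 values shown sit, is all that can be read from this set. Next comes compound 4 `CCOc1ccc(C(=O)N(C)Nc2c(Cl)cccc2Cl)cc1`, which differs from compound 3 by methyl in place of hydrogen on an amide-type nitrogen with methyl in place of hydrogen on an amide-type nitrogen. Going by the values given here, no measured step covers this change. Among the compounds with values here, the only step between measured compounds is a step that the two limits leave unreadable from compound 1 to compound 2 and it concerns bromo in place of butoxy on an aromatic carbon, so it offers no size to carry over. With no readable step to go on, no change beyond the scatter is expected in this assay in either direction. This expectation rests on compound 3, whose reading is > 100000 nM as a limit. The expected step is a step that the limit leaves unreadable from compound 3 to compound 4 on this estimate. For compound 4 the estimated value is 120000 nM with an expected range from 50000 nM to 300000 nM for the measurement. A result given only as a limit is the likeliest outcome.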

Compound 4, half-maximal cytotoxic concentration: > 100000 nM
Compound 4: a limit, no number; the forecaster's own chance of this, stated with the estimate: 85%; the middle value is on the limit's open side.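

In this assay compound 4 gives > 100000 nM, which is a limit and not a number. Going by these compounds alone, compound 3 and compound 4 are both known only as limits, so no step between them can be read. The compounds shown leave open what half-maximal cytotoxic concentration any of them has, and whether methyl on the amide-type nitrogen changes it, with one reading available: the limit of > 100000 nM in this assay, at which 4 of the 4 values shown sit.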